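Piperazine nitrogen substituent swap in MCHR1 antagonist series

The source may hold more compounds than are shown below. What is called first, only, known or untested is meant among the compounds shown, and "the series" means these compounds.

Measured compounds:
Compound 1, `CCC1(O)CCN(c2nc(C)c3cc(NC(=O)COc4ccc(Cl)cc4)ccc3n2)CC1`: 384 nM
Compound 2, `Cc1nc(N2CCC(C)(O)CC2)nc2ccc(NC(=O)COc3ccc(Cl)cc3)cc12`: 827 nM
Compound 3, `Cc1nc(N2CCN(C3CCOCC3)CC2)nc2ccc(NC(=O)COc3ccc(Cl)cc3)cc12`: 115 nM

The three compounds were tested in a functional assay on CHO-K1 cells for antagonist activity at melanin-concentrating hormone receptor 1 (Homo sapiens), read by inositol phosphate accumulation; on this read-out lower numbers stand for stronger inhibition and higher numbers for weaker inhibition. They share a common core and differ in the group attached to the ring nitrogen of that core. Compound 3, `Cc1nc(N2CCN(C3CCOCC3)CC2)nc2ccc(NC(=O)COc3ccc(Cl)cc3)cc12`, stands lowest of the three numbers; compound 1 sits at 384 nM and compound 2 at 827 nM, both beyond the scatter from compound 3.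

Among the measured compounds shown here, the only step between compounds that differ in one place is a 2.2-fold higher number from compound 1 to compound 2 (0.33 log units; beyond the scatter), which concerns a substituent on a saturated ring carbon and not the amine nitrogen that changes here. Compound 4, `Cc1nc(N2CCN(CC(C)(C)C)CC2)nc2ccc(NC(=O)COc3ccc(Cl)cc3)cc12`, differs from compound 3 by neopentyl in place of oxan-4-yl on an amine nitrogen in a ring. For the measured compounds named here, no measured step bears on a change at this position, so nothing in the data points to a large move in either direction. Compound 4 is therefore expected to remain near compound 3, with an estimated step of a 1.4-fold higher number from compound 3 to compound 4 (0.14 log units; within the scatter). The estimate for compound 4 in this assay is 160 nM, with a range from 50 nM to 500 nM.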

Compound 4, half-maximal inhibitory concentration: 246 nM
Estimate against measurement, compound 4: 1.5-fold (0.19 log units) below; low and high end bracket the measured number.
By their numbers in this assay, from the lowest: compound 3; then compounds 4 and 1 (each within the scatter of the next); then compound 2.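

In this assay, among the compounds shown here, the first step at this position shows that the group on the amine nitrogen in a ring does matter: exchanging oxan-4-yl, with its six-membered ring and hydrogen-bond acceptor, for neopentyl, which has neither, gives a 2.1-fold higher number from compound 3 to compound 4 (0.33 log units; beyond the scatter). The neopentyl compound also places the piperazine-bearing compounds against the hydroxypiperidines, and the two comparisons differ, with a 3.4-fold lower number from compound 2 to compound 4 (0.53 log units; beyond the scatter) but only a 1.6-fold lower number from compound 1 to compound 4 (0.19 log units; within the scatter), so replacing the whole group on the aromatic carbon has a clear effect against one hydroxypiperidine and no readable effect against the other. The data shown offer no measurement that could explain the step at the amine nitrogen.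

The compounds shown leave open whether the ring or the ring oxygen of oxan-4-yl is what separates compound 3 from compound 4, a question that a cyclohexyl group on the same nitrogen would help to settle. They also leave open how the number responds to a much smaller group at this nitrogen, such as methyl, or to a chain carrying an ether oxygen, such as 2-methoxyethyl.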